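The compounds below may be only part of what the source reports. "The series", "measured", "known", "first", "only" and "open" are said of these compounds alone.

Compound 1 `O=C(Nc1cccc(-n2cc(-c3ccncc3)c(-c3cc(O)cc(Cl)c3)n2)c1)Nc1ccc(Cl)c(C(F)(F)F)c1` was tested in a functional assay on UO-31 cells (Homo sapiens) for inhibition, read by sulforhodamine B assay, with a stated time of 48 h, tested at 10 uM (a lower number here means a stronger effect, a higher number a weaker effect of the compound at the concentration tested), where compound 1 gives 18.5%. Compound 2 `COc1cc(Cl)cc(-c2nn(-c3cccc(NC(=O)Nc4ccc(Cl)c(C(F)(F)F)c4)c3)cc2-c2ccncc2)c1` differs from it by methyl in place of hydrogen on an oxygen on an aromatic ring, and in this assay compound 2 gives 11.1%; the resulting step, a number 7.4 percentage points lower from compound 1 to compound 2 (within the scatter), is a small one. Compound 3 `O=C(Nc1cccc(-n2cc(-c3ccncc3)c(-c3cc(O)cc(Cl)c3)n2)c1)c1cc(C(F)(F)F)cc(C(F)(F)F)c1` carries a different core, and the difference between the core of compound 3 and that of compound 1 is not broken down here. In this assay compound 3 gives 49.2%, the highest of the three numbers, and its distance to both compound 1 and compound 2 lies beyond the scatter. Among the measured compounds shown here, compound 4 `COc1cc(Cl)cc(-c2nn(-c3cccc(NC(=O)c4cc(C(F)(F)F)cc(C(F)(F)F)c4)c3)cc2-c2ccncc2)c1` has not yet been measured; it differs from compound 3 by methyl in place of hydrogen on an oxygen on an aromatic ring, which is the same change, at the same place, as the one from compound 1 to compound 2. Since that change produced a number 7.4 percentage points lower from compound 1 to compound 2 (within the scatter), a step of similar size is expected here, namely a number 7.2 percentage points lower from compound 3 to compound 4 (within the scatter). Compound 4 is therefore estimated to give 42% in this assay, with an expected range from 27% to 58%.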

Compound 4, a percentage reported as activity, at one concentration (the size of the read-out at that concentration, not a potency): 54.3%
The estimate for compound 4 lay 12.3 percentage points below the measured number, and the stated range covers the measured number.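

In this assay, going from hydroxy to methoxy on the second core gives a number 5.1 percentage points higher from compound 3 to compound 4 (within the scatter). Set beside the same change on the first core, this step does not differ from the earlier one by more than two such steps can be expected to differ: the same change on two cores in this assay, a number 7.4 percentage points lower (within the scatter) from compound 1 to compound 2 and a number 5.1 percentage points higher (within the scatter) from compound 3 to compound 4, 12.5 percentage points apart, within the scatter of two such steps. Among the compounds shown here, the change from 3-chloro-5-hydroxyphenyl to 3-chloro-5-methoxyphenyl therefore carries over between these two cores in the sense that it leaves the read-out within the scatter on both, but with only two pairs, each read at a single concentration, this does not show that it would do so on other cores, nor does it give the direction of any real effect.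

The compounds shown leave open whether a longer chain such as ethyl on that oxygen would also stay within the scatter on these cores. They also leave open what an amine or a carboxylic acid in place of the hydroxy would do.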